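The source may report more compounds than this note shows. Statements on the series, on what has been measured and on what is new or still open speak of the compounds shown alone.

Measured so far in a physicochemical assay for solubility, read by spectrophotometry, in phosphate buffer, with a stated time of 2 h, at pH 7.4; on this read-out lower numbers stand for lower solubility and higher numbers for higher solubility:
- compound 1 `COc1ccc2[nH]c(C(=O)N3CC(=O)N(Cc4ccccc4)[C@@H](CCc4ccccc4)C3)cc2c1` gives 4400 nM
- compound 2 `COc1ccc2[nH]c(C(=O)N3CC(=O)N(Cc4ccccc4)[C@@H](COc4ccccc4)C3)cc2c1` gives 12200 nM

Among the measured compounds shown here, compound 2 holds the higher of the two numbers; its only neighbour is compound 1, and the step of a 2.8-fold higher number from compound 1 to compound 2 (0.44 log units; beyond the scatter) separates them, beyond the scatter. Compound 3 `COc1ccc2[nH]c(C(=O)N3CC(=O)N(Cc4ccccc4)[C@@H](CN4CCCCC4)C3)cc2c1` differs from compound 2 by piperidin-1-yl in place of phenoxy on a saturated chain carbon bound to a saturated ring carbon. For the measured compounds named here, the one measured step bears on it only in part: it shows that an exchange at this same place, on a saturated chain carbon bound to a saturated ring carbon, moved this assay by a modest amount, but it swapped an aryl group for another aryl group, whereas here a saturated amine ring enters. Going by the values given here, no measured pair covers that kind of exchange, so the direction rests on the position alone. A further rise is expected, a 3.3-fold higher number from compound 2 to compound 3 (0.52 log units; beyond the scatter). Compound 3 is therefore estimated at 40000 nM, with a range from 12000 nM to 150000 nM.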

Compound 3, solubility: > 25000 nM
Compound 3 ended at the assay's limit; the forecaster's own chance of this, stated with the estimate: 10%; the middle value does not contradict the limit.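

In this assay compound 3 gives > 25000 nM, which is a limit of the assay and not a number: the limit of > 25000 nM in this assay, at which 1 of the 3 values shown sits.

The step therefore has a floor but no known size: an at least 2.0-fold higher number from compound 2 to compound 3 (0.31 log units; beyond the scatter), and over the whole set, an at least 5.6-fold higher number from compound 1 to compound 3 (0.75 log units; beyond the scatter). Both steps lie beyond the scatter, so this position, on a saturated chain carbon bound to a saturated ring carbon, takes a non-aromatic ring with a hetero atom in place of a carbon-only aromatic ring, and the number still rises.

The compounds shown leave open whether the rise goes with the ring nitrogen or with the loss of the aromatic ring, a question that cyclohexyl at this place, paired with piperidin-1-yl, would address. An open-chain amine such as dimethylamino would likewise test whether the saturated ring itself matters.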